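The source may report more compounds than this note shows. Statements on the series, on what has been measured and on what is new or still open speak of the compounds shown alone.

Compound 1 `COc1ccc2c(c1)[n+]([O-])nc(NCOC(C)c1ccccc1)[n+]2[O-]`: 3130 nM
Compound 2 `[O-][n+]1nc(NCOCc2ccc(C(F)(F)F)cc2)[n+]([O-])c2ccccc21`: 8420 nM
Compound 3 `COc1ccc(COCNc2n[n+]([O-])c3ccccc3[n+]2[O-])cc1`: 7640 nM

All three have been tested in a functional assay on A549 cells (Homo sapiens) for cytotoxicity, read by MTT assay, with a stated time of 72 h; a lower number here means a stronger inhibitor, a higher number a weaker inhibitor. Compound 1 gives the lowest number of the three; compound 3 gives 7640 nM, and compound 2 gives 8420 nM, both gaps to compound 1 beyond the usual scatter of this assay. Compound 4 `CCCCCOCNc1n[n+]([O-])c2cc(OC)ccc2[n+]1[O-]` has not yet been measured. It differs from compound 1 in one place: pentyl in place of 1-phenylethyl on an oxygen on a saturated carbon. Within the data shown here, the only single-point step measured so far, a 1.1-fold lower number from compound 2 to compound 3 (0.04 log units; within the scatter), concerns a group on an aromatic carbon and stayed within the scatter; it does not involve the oxygen on a saturated carbon where compound 4 changes, so no measured step speaks directly to this exchange. Compounds 2 and 3 differ from compound 1 in more than one place, so their higher numbers cannot be tied to any single change. Without a direct precedent, the step of a 1.8-fold higher number from compound 1 to compound 4 (0.24 log units; within the scatter) is expected to be a modest rise, a weaker inhibitor than compound 1 but within a similar range. Compound 4 is therefore estimated at 5500 nM, with a range of 2200 nM to 14000 nM.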

Compound 4, half-maximal inhibitory concentration: 5040 nM
Compound 4: the middle estimate sits 1.1-fold (0.04 log units) above what was measured, within the range that was stated.
By their numbers in this assay, from the lowest: compounds 1, 4, 3 and 2 (each within the scatter of the next, the first and the last beyond it).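

In this assay, the exchange at this oxygen on a saturated carbon gives a 1.6-fold higher number from compound 1 to compound 4 (0.21 log units; within the scatter), so the two compounds cannot be told apart here. Among these compounds, this is the first measured step at this place, and it shows that, in this pair, an open pentyl chain with no ring can stand where 1-phenylethyl, with its six-membered aromatic ring and larger count of heavy atoms, stood without a difference that the assay can resolve. No measurement shown here explains this result, so the outcome stays an observation about these two compounds only.

As far as these compounds go, a single exchange cannot show how much freedom this place allows, and it remains open whether a longer chain, or a chain ending in an amine or a carboxylic acid, would also give a number within the scatter of compound 1. From the compounds shown here alone, both compounds in this step also carry the methoxy group on the shared core, so it remains open whether the same exchange would give a similar result on a core with a fluorine in that group's place.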